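The source may report more compounds than this note shows. Statements on the series, on what has been measured and on what is new or still open speak of the compounds shown alone.

In a functional assay on MCF7 cells (Homo sapiens) for inhibition, read by MTT assay (a higher number here means a weaker inhibitor, a lower number a stronger inhibitor), compound 1 `COc1cc2ncnc(Nc3ccc(NC(=O)c4ccccc4F)cc3)c2cc1OC` gives 11000 nM and compound 2 `COc1cc2ncnc(Nc3ccc(NC(=O)c4cccc(I)c4)cc3)c2cc1OC` gives 30000 nM. Compound 3 `COc1cc2ncnc(Nc3ccc(NC(=O)c4ccc(C(F)(F)F)cc4)cc3)c2cc1OC` gives > 100000 nM, which is only a limit of the assay and not a number. That is where it stands: the limit of > 100000 nM in this assay, at which 1 of the 3 values shown sits.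

Compound 4 `COc1cc2ncnc(Nc3ccc(NC(=O)c4cc(F)ccc4Br)cc3)c2cc1OC` has not yet been measured. It keeps the shared core, and the change is 2-bromo-5-fluorophenyl in place of 4-(trifluoromethyl)phenyl on a carbonyl carbon.

All three measured steps swap the group at this same place. Two of them lead into compound 3, namely an at least 9.0-fold higher number from compound 1 to compound 3 (0.95 log units; beyond the scatter) and an at least 3.3-fold higher number from compound 2 to compound 3 (0.52 log units; beyond the scatter). The third is a 2.7-fold higher number from compound 1 to compound 2 (0.44 log units; beyond the scatter). Leaving the 4-(trifluoromethyl)phenyl group should therefore undo part of that loss, since the entering group, like those of compound 1 at 11000 nM and compound 2 at 30000 nM, is a halogen-bearing phenyl.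

The expected change is an at least 4.5-fold lower number from compound 3 to compound 4 (0.65 log units; beyond the scatter), toward a lower number and a stronger inhibitor. Compound 4 is estimated at 22000 nM, with an expected range of 7000 nM to 70000 nM.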

Compound 4, half-maximal inhibitory concentration: 26000 nM
Compound 4: middle estimate off by 1.2-fold (0.07 log units), on the low side, within the range that was stated.
By their numbers in this assay, from the lowest: compound 1; then compounds 4 and 2 (each within the scatter of the next). At a limit, above all of these: compound 3.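

Compound 3 remains a limit in this assay and not a number: the limit of > 100000 nM in this assay, at which 1 of the 4 values shown sits. Putting 2-bromo-5-fluorophenyl in place of 4-(trifluoromethyl)phenyl on the carbonyl carbon returns a measurable value, with an at least 3.8-fold lower number from compound 3 to compound 4 (0.58 log units; beyond the scatter), so this position tolerates a phenyl ring carrying two different halogens at least as well as it tolerates the trifluoromethyl group. The new group cannot be told apart from 3-iodophenyl, with a 1.2-fold lower number from compound 2 to compound 4 (0.06 log units; within the scatter), while 2-fluorophenyl keeps a modest edge, with a 2.4-fold higher number from compound 1 to compound 4 (0.37 log units; beyond the scatter).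

The compounds shown cannot tell whether the bromine or the fluorine of the new group sets its value. On these data alone, all four carry a phenyl ring with halogen or trifluoromethyl at this place, so how an amine or a carboxylic acid on that ring would read remains open.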